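The source may hold more compounds than are shown below. What is called first, only, known or untested is meant among the compounds shown, and "the series" means these compounds.

In a functional assay on MCF7 cells (Homo sapiens) for cytotoxicity, read by MTT assay, with a stated time of 96 h (on this read-out higher numbers stand for weaker inhibition and lower numbers for stronger inhibition), compound 1 (`COc1cc(C(=O)c2cn(-c3ccccc3C)cc2-c2ccccc2)cc(OC)c1OC`) gives 2200 nM and compound 2 (`COc1ccccc1-n1cc(C(=O)c2cc(OC)c(OC)c(OC)c2)c(-c2ccccc2)c1`) gives 150 nM with methoxy in place of methyl. Compound 3 (`COc1cc(C(=O)c2cn(-c3ccccc3)cc2-c2cccc(Cl)c2)cc(OC)c1OC`) at 540 nM lies between these two, second highest of the three numbers.

Compound 4 (`COc1cc(C(=O)c2cn(-c3ccccc3)cc2-c2ccc([N+](=O)[O-])cc2)cc(OC)c1OC`) departs from compound 3 in one place, on an aromatic carbon of a five-membered aromatic ring with 1 nitrogen, with 4-nitrophenyl in place of 3-chlorophenyl (4-nitrophenyl in place of 3-chlorophenyl on an aromatic carbon). Among the compounds with values here, no measured step changes the group at this place. Within the data shown here, the only step available, a 15-fold lower number from compound 1 to compound 2 (1.17 log units; beyond the scatter), lies elsewhere on the molecule and shows only that a single exchange moved the number a long way between compound 1 and compound 2.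

A small step in this assay is therefore expected, leaning towards a higher number and possibly not beyond the scatter. The estimated change is a 1.5-fold higher number from compound 3 to compound 4 (0.17 log units; within the scatter) on this thin evidence. For compound 4 the estimated value is 800 nM with an expected range of 200 nM to 3000 nM in this assay as a working figure.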

Compound 4, half-maximal inhibitory concentration: 590 nM
Beside the measured number, compound 4's estimate is 1.4-fold (0.13 log units) above it; measured number inside the range.
By their numbers in this assay, from the lowest: compound 2; then compounds 3 and 4 (each within the scatter of the next); then compound 1.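

In this assay, the aromatic carbon of the five-membered aromatic ring with 1 nitrogen accepts 4-nitrophenyl in place of 3-chlorophenyl with no change beyond the scatter (a 1.1-fold higher number from compound 3 to compound 4 (0.04 log units; within the scatter)). The entering group has 9 heavy atoms and 2 hydrogen-bond acceptors against 7 and 0 for the group that leaves, yet the number holds, so at this place these differences in the two groups carry no readable cost in this assay. No measured property is available to account for this result.

The step exchanges the substituent and its place on the phenyl together, so the contribution of each remains unresolved. Going by these compounds, whether a phenyl carrying an amine or a carboxylic acid would hold the number at this place also remains open.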